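Adding a tert-butoxycarbonyl group to compound 2

A few compounds are considered here, and "the series" means these few. Any claim that something is new, unique, unknown or untested is made for them only; others in the source may bear on it.

Compound 1 `CCN1CCc2c(sc(NC(=O)Nc3ccc4ccccc4c3)c2C(N)=O)C1`: 1780 nM
Compound 2 `CN1CCc2c(sc(NC(=O)Nc3ccc(Cl)cc3)c2C(N)=O)C1`: 4700 nM

Within the data shown here, only these two compounds have numbers so far. In a functional assay (strain AB) with Danio rerio as the target, read by microscopy, with a stated time of 1 h (a lower number here means that less compound is needed, a higher number that more compound is needed for the effect), compound 2 gives 4700 nM, the higher of the two numbers. Compound 1 gives 1780 nM, and the gap between them lies beyond the scatter. The two compounds differ in more than one place, so their gap does not measure any single structural change.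

The next compound to be tested is compound 3 `CC(C)(C)OC(=O)CN1CCc2c(sc(NC(=O)Nc3ccc(Cl)cc3)c2C(N)=O)C1`, which has no measured value yet. Its structure has tert-butoxycarbonyl in place of hydrogen on a saturated chain carbon bound to an amine nitrogen in a ring. Cut one bond further out, the same difference reads methyl to (tert-butoxycarbonyl)methyl.

Among the measured compounds shown here, no measured pair shows this change alone, which leaves the direction open and the expected range wide. The expectation in this assay is therefore no step beyond the scatter. For compound 3 the estimate amounts to an expected step of a 1.0-fold lower number from compound 2 to compound 3 (0.02 log units; within the scatter). The estimated value for compound 3 is 4500 nM, with an expected range from 1200 nM to 18000 nM.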

Compound 3, half-maximal effective concentration: > 25000 nM
Compound 3: no number, only a limit (the forecaster's own chance of this, stated with the estimate: 10%); at least 5.5-fold (0.74 log units) between middle value and limit.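

The value of compound 3 is a limit and not a number: the limit of > 25000 nM in this assay, at which 1 of the 3 values shown sits. Even so, it gives the first comparison in this assay that isolates one place: tert-butoxycarbonyl in place of hydrogen on a saturated chain carbon bound to an amine nitrogen in a ring goes with an at least 5.3-fold higher number from compound 2 to compound 3 (0.72 log units; beyond the scatter), so more compound is needed for the effect once this group is present. Compound 1 and compound 2 could not show this, since they differ in more than one place, and the result now shows that this position does not tolerate every change without a shift beyond the scatter.

As far as these compounds go, with only a limit in hand, the full size of the step stays unknown, and a single group cannot separate the contribution of the tert-butyl part from that of the carbonyl. From the compounds shown here alone, whether a carboxylic acid, an amine or a longer chain at the same place would give a similar step remains open, as does whether tert-butoxycarbonyl would have the same result on compound 1.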